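The source may hold more compounds than are shown below. What is called first, only, known or untested is meant among the compounds shown, and "the series" means these compounds.

Compound 1 `Cc1ccc(S(=O)(=O)c2cnc3c(F)cccc3c2N2CCC(C)CC2)cc1`: 93%
Compound 2 `Cc1ccc(S(=O)(=O)c2cnc3c(F)cccc3c2N2CCC(C)CC2)cc1F`: 93%

In an assay on isolated protein for displacement of a labelled ligand from metabotropic glutamate receptor 5 (Homo sapiens), with a stated time of 60 min, tested at 1 uM (a higher number here means more inhibition at the concentration tested (going by the name of the read-out), a lower number less inhibition), compound 2 gives 93% and stands level with compound 1, which gives 93%. Going by the values given here, the single measured step, no change at the digits printed from compound 1 to compound 2 (within the scatter), shows that fluoro in place of hydrogen leaves the read-out unchanged. Compound 3 `CC1CCN(c2c(S(=O)(=O)c3cccc(F)c3)cnc3c(F)cccc23)CC1` differs from compound 2 as follows: hydrogen in place of methyl on an aromatic carbon. Among the compounds with values here, no measured step removes a methyl, so the step from compound 1 to compound 2 is only an indirect guide; it lay within the scatter, and a flat outcome with a small downward allowance is therefore expected: a number 5 percentage points lower from compound 2 to compound 3 (within the scatter). Compound 3 is estimated at 88%, with a range from 70% to 97%.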

Compound 3, a percentage reported as inhibition, at one concentration (the size of the read-out at that concentration, not a potency): 62%
Compound 3: middle estimate off by 26 percentage points, on the high side; the whole stated range lies above it.
By their numbers in this assay, from the lowest: compound 3; then compounds 1 and 2 (each within the scatter of the next).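

In this assay, this position on the aromatic ring proves sensitive in a way the fluoro change did not reveal: removing the methyl, with hydrogen entering in its place, gives a number 31 percentage points lower from compound 2 to compound 3 (beyond the scatter). Read as 3-fluorophenyl in place of 4-methylphenyl on the sulfonyl sulfur, the change gives a number 31 percentage points lower from compound 1 to compound 3 (beyond the scatter), so the fluoro group does not make up for the missing methyl. Nothing measured here gives a reason for this loss. Going by these compounds, whether a chloro, methoxy or ethyl group in the methyl's place would restore the read-out remains open.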